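This account rests on a few compounds, and the source may have more. Where it says the series, first, only, none or still open, it means among the compounds named here.

In an ADME assay on liver (Homo sapiens) for metabolic stability, read by LC-MS, using microsomes (on this read-out lower numbers stand for slow clearance and higher numbers for fast clearance), compound 1 (`Fc1ccc(CC[C@@H]2CN(Cc3c[nH]c4cc(Cl)ccc34)CCC2(F)F)cc1`) gives 99 mL/min/kg and compound 2 (`COc1ccc2c(CN3CCC(F)(F)[C@H](CCc4ccc(F)cc4)C3)c[nH]c2c1`) gives 298 mL/min/kg as the higher of the two numbers. Compound 3 (`COc1ccc2c(CN3CCC(F)(F)[C@H](CCc4cccc(F)c4)C3)c[nH]c2c1`) has not yet been measured. Its difference from compound 2 (3-fluorophenyl in place of 4-fluorophenyl on a saturated chain carbon, two bonds along the chain from a saturated ring carbon) is 3-fluorophenyl in place of 4-fluorophenyl on a saturated chain carbon, two bonds along the chain from a saturated ring carbon. Among the measured compounds shown here, the only measured step (a 3.0-fold higher number from compound 1 to compound 2 (0.48 log units; beyond the scatter)) is modest and beyond the scatter. For the measured compounds named here, that step is methoxy in place of chloro on an aromatic carbon, a different place, and no measured pair tests the present change. It offers no direction here, so no step beyond the scatter is expected in this assay for compound 3. The estimated step (a 1.0-fold lower number from compound 2 to compound 3 (0.01 log units; within the scatter)) stays within the scatter. Compound 3 is expected at 290 mL/min/kg with an estimated range from 160 mL/min/kg to 500 mL/min/kg as the likely span.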

Compound 3, clearance: 300 mL/min/kg
For compound 3 the middle estimate is 1.0-fold (0.01 log units) below the measured one; measured number inside the range.
By their numbers in this assay, from the lowest: compound 1; then compounds 2 and 3 (each within the scatter of the next).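

Placing 3-fluorophenyl in place of 4-fluorophenyl on a saturated chain carbon, two bonds along the chain from a saturated ring carbon, gives a 1.0-fold higher number from compound 2 to compound 3 (0.00 log units; within the scatter) in this assay and so stays within the scatter. Among the compounds shown here, this is the first measured pair to test this position, since the earlier step concerned only methoxy and chloro on an aromatic carbon, and it shows that with methoxy on the core this read-out does not separate the two fluorophenyl groups. Nothing available explains this outcome.

On these data alone, whether an unsubstituted phenyl, a pyridine ring or a longer chain at this position would shift the clearance remains open. As far as these compounds go, it is also open whether the same fluorophenyl exchange would read alike with chloro in place of methoxy.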